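Working notes on ring-nitrogen acylation in a cytotoxicity series

The source may report more compounds than this note shows. Statements on the series, on what has been measured and on what is new or still open speak of the compounds shown alone.

Measured so far:
compound 1, `CCN1C/C(=C\c2ccc(OC)c(OC)c2)C(=O)/C(=C/c2ccc(OC)c(OC)c2)C1`: 8500 nM in a functional assay on NCI-H1975 cells (Homo sapiens) for cytotoxicity, read by MTT assay, with a stated time of 72 h; a higher number here means a weaker inhibitor, a lower number a stronger inhibitor
compound 2, `COc1cc(/C=C2\CNC/C(=C\c3cc(OC)c(OC)c(OC)c3)C2=O)cc(OC)c1OC`: 4000 nM in this assay

Compound 2 stands at the lower of the two numbers in this assay; compound 1 sits at a higher number, and that gap lies beyond the usual scatter. Going by the values given here, compound 1 differs from compound 2 in more than one place, so no single-change step between measured compounds is available, and the two values show only that compound 2 gives the lower number.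

Compound 3, `COc1cc(/C=C2\CN(C(=O)C(C)C)C/C(=C\c3cc(OC)c(OC)c(OC)c3)C2=O)cc(OC)c1OC`, is not yet measured. It differs from compound 2 in one place:
isopropylcarbonyl in place of hydrogen on an amine nitrogen in a ring
Among the compounds with values here, nothing among the measured compounds speaks to a change of this kind, so the expectation rests on the value of compound 2 alone. For the step in this assay, a small move is expected, if any, with a slight lean toward a lower number but not clearly beyond the scatter. Compound 3 is estimated at 3000 nM in this assay, with a range from 800 nM to 12000 nM. This estimate means an expected step of a 1.3-fold lower number from compound 2 to compound 3 (0.12 log units; within the scatter).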

Compound 3, half-maximal inhibitory concentration: 1900 nM
The estimate for compound 3 lay 1.6-fold (0.20 log units) above the measured number; measured number inside the range.
By their numbers in this assay, from the lowest: compound 3; then compound 2; then compound 1.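

Isopropylcarbonyl in place of hydrogen on an amine nitrogen in a ring gives, in this assay, a 2.1-fold lower number from compound 2 to compound 3 (0.32 log units; beyond the scatter), a modest step but the first single-change step in the series. The ring nitrogen of compound 2 therefore need not stay unsubstituted: an acyl group of this size is accepted there, and the number moves lower rather than higher. No supporting data bear on what lies behind this step, so it stands as an observation on one pair.

The compounds shown leave open whether the step belongs to acylation in general or to isopropylcarbonyl in particular, since a single pair cannot separate the two, and compound 1 differs from the others in more than one place and so does not speak to the question. Acetyl, a longer acyl chain, benzoyl, or an acyl chain ending in an amine or a carboxylic acid on the same nitrogen would show whether the number keeps falling, levels off or turns back.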